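Swapping an Amide Aryl Group for a Carbamoyl Arm

A few compounds are considered here, and "the series" means these few. Any claim that something is new, unique, unknown or untested is made for them only; others in the source may bear on it.

Compound 1 `COc1cc(-c2nn(-c3cccc(NC(=O)c4cccc(C(F)(F)F)c4)c3)cc2-c2ccncc2)ccc1Cl` is tested in a functional assay on PC-3 cells (Homo sapiens) for inhibition, read by sulforhodamine B assay, with a stated time of 48 h (on this read-out higher numbers stand for weaker inhibition and lower numbers for stronger inhibition), and gives 1230 nM. That is the highest of the two numbers recorded here, meaning the weaker inhibitor of the pair. For the measured compounds named here, compound 2 `O=C(Nc1cccc(-n2cc(-c3ccncc3)c(-c3ccc(Cl)c(O)c3)n2)c1)Nc1cc(C(F)(F)F)cc(C(F)(F)F)c1` gives 320 nM in this assay, a value beyond the usual scatter and so a genuinely stronger result, though compound 2 differs from compound 1 in more than one place and no single step links them. Compound 3 `COc1cc(-c2nn(-c3cccc(NC(=O)Nc4ccc(Cl)c(Cl)c4)c3)cc2-c2ccncc2)ccc1Cl` has not yet been measured. Compared with compound 1 the change is (3,4-dichlorophenyl)amino in place of 3-(trifluoromethyl)phenyl on a carbonyl carbon. Because compound 2 gives 320 nM with a related carbamoyl arrangement, the step from compound 1 to compound 3 is expected to be a moderate move toward a lower number, a 2.5-fold lower number from compound 1 to compound 3 (0.39 log units; beyond the scatter). Compound 3 is therefore estimated at 500 nM, within a range of 150 nM to 1600 nM.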

Compound 3, half-maximal inhibitory concentration: 550 nM
Compound 3: the middle estimate sits 1.1-fold (0.04 log units) below what was measured; the range from low to high includes it.
By their numbers in this assay, from the lowest: compounds 2 and 3 (each within the scatter of the next); then compound 1.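

In this assay, for the compounds shown here, the swap on the carbonyl carbon gives a 2.2-fold lower number from compound 1 to compound 3 (0.35 log units; beyond the scatter) and provides the first reading of a change in one place, a modest one that lies beyond the scatter. It shows that this position accepts (3,4-dichlorophenyl)carbamoyl in place of (3-(trifluoromethyl)phenyl)carbonyl with the rest of compound 1 unchanged, and the entering arm adds an amide-type hydrogen-bond donor. The change also replaces trifluoromethyl with two chlorines on the ring, and no measurement here explains the shift or assigns it to either part of the change.

Still open, as far as these compounds go, is whether the amide-type nitrogen alone, with 3-(trifluoromethyl)phenyl kept on it, would give the same shift. Also open, from the compounds shown here alone, is how a saturated ring such as cyclohexyl or a simple unsubstituted phenyl would read at this position.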